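The compounds below may be only part of what the source reports. "The series", "measured", "known", "first", "only" and "open" are said of these compounds alone.

Compound 1 `CS(=O)(=O)Nc1ccc2c(c1)S(=O)(=O)N=C(c1c(O)c(-c3cccs3)nn(CC3CCC3)c1=O)N2`: > 1 h (a limit)
Compound 2 `CC(C)Cn1nc(-c2cccs2)c(O)c(C2=NS(=O)(=O)c3cc(NS(C)(=O)=O)ccc3N2)c1=O`: > 1 h (a limit)
Compound 3 `CS(=O)(=O)Nc1ccc2c(c1)S(=O)(=O)N=C(c1c(O)c(-c3cccs3)nn(CC3(C(F)(F)F)CCC3)c1=O)N2`: 1 h

All three compounds were tested in an in vitro ADME assay on microsomes from liver (Homo sapiens) for metabolic stability, tested at 5 uM; on this read-out lower numbers stand for a shorter-lived compound and higher numbers for a longer-lived compound. Among the compounds with values here, compound 3 gives the only actual number in the set, 1 h. Compound 1 and compound 2 both rest on (the limit of > 1 h in this assay, at which 2 of the 3 values shown sit), so neither can be ranked against compound 3 by a number.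

Compound 4 `CS(=O)(=O)Nc1ccc2c(c1)S(=O)(=O)N=C(c1c(O)c(-c3cccs3)nn(Cc3ccccc3)c1=O)N2` has not yet been measured. It differs from compound 3 as follows: phenyl in place of 1-(trifluoromethyl)cyclobutyl on a saturated chain carbon bound to an aromatic nitrogen. Cut one bond further out, the same difference reads (1-(trifluoromethyl)cyclobutyl)methyl to benzyl.

Within the data shown here, three measured steps bear on this change, though only loosely. The substituent at this place differs in a step that the two limits leave unreadable from compound 1 to compound 2 and in a number no higher from compound 2 to compound 3 (the limit leaves the size open), while the trifluoromethyl group alone accounts for a number no higher from compound 1 to compound 3 (the limit leaves the size open). None of these steps has a readable size, and none of them brings in a phenyl group, so they give no direction for the new change.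

The expectation therefore starts from compound 3 at 1 h. The expected size of no change at the digits printed from compound 3 to compound 4 (within the scatter) stays within the usual scatter, with no direction favoured. Compound 4 is expected at 1 h, with an estimated range of 0.5 h to 2 h.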

Compound 4, half-life: > 1 h
Compound 4 ended at the assay's limit (the forecaster's own chance of this, stated with the estimate: 45%); the middle value sits exactly at the limit.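

In this assay, within the data shown here, phenyl in place of 1-(trifluoromethyl)cyclobutyl on a saturated chain carbon bound to an aromatic nitrogen gives a number no lower from compound 3 to compound 4 (the limit leaves the size open), and this is the first step in the set that brings an aromatic ring to this place. Compound 4 gives > 1 h, which is a limit of the assay and not a number. The steps to compound 4 from compound 1 and from compound 2 cannot be read, and the set now offers little that can be ordered by number: the limit of > 1 h in this assay, at which 3 of the 4 values shown sit.

As far as these compounds go, how far compound 4 lies from compound 3 stays open, as does any ranking of compound 4 against compound 1 or compound 2. Also open, from the compounds shown here alone, is how a carboxylic acid or an amine on the phenyl ring, or a phenethyl group in place of benzyl, would read in this assay.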